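Pyridinyl isomer swap on the shared core, cytotoxicity

A few compounds are considered here, and "the series" means these few. Any claim that something is new, unique, unknown or untested is made for them only; others in the source may bear on it.

Compound 1 `c1ccc(C(c2ccco2)N2CCN(c3ncnc4c3cnn4-c3ccccc3)CC2)cc1` and compound 2 `c1ccc(C(c2ccccn2)N2CCN(c3ncnc4c3cnn4-c3ccccc3)CC2)cc1` share one core and differ only in the furan-2-yl or pyridin-2-yl group on the chain carbon. In a functional assay on cells (Rhabdomyosarcoma cell, Homo sapiens) for cytotoxicity (on this read-out higher numbers stand for weaker inhibition and lower numbers for stronger inhibition), compound 1 gives > 25000 nM, which is a limit of the assay. In this assay compound 2 gives > 25000 nM, also a limit. The step that the two limits leave unreadable from compound 1 to compound 2 cannot be sized; the limit of > 25000 nM in this assay, at which 2 of the 2 values shown sit, is all that is shown. Compound 3 `c1ccc(C(c2ccncc2)N2CCN(c3ncnc4c3cnn4-c3ccccc3)CC2)cc1` differs from compound 2 by pyridin-4-yl in place of pyridin-2-yl on a saturated chain carbon bound to an amine nitrogen in a ring and an aromatic carbon. No readable step bears on this change, so no step beyond the scatter is expected, a step that the limit leaves unreadable from compound 2 to compound 3. Compound 3 is therefore expected at 50000 nM, between 20000 nM and 200000 nM, most likely again as a limit.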

Compound 3, half-maximal inhibitory concentration: > 25000 nM
Compound 3: only a limit was reported; the forecaster's own chance of this, stated with the estimate: 85%; the middle value is on the limit's open side.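

No step can be read among compound 1, compound 2 and compound 3, as each result in this assay is a limit: the limit of > 25000 nM in this assay, at which 3 of the 3 values shown sit.

The compounds shown leave open whether furan-2-yl, pyridin-2-yl and pyridin-4-yl differ at all in this assay.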